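The source may report more compounds than this note shows. Statements on the series, on what has been measured and on what is new or still open speak of the compounds shown alone.

Measured so far:
- compound 1 `CCN(CCCCn1sc2cc(OC)c(OC)cc2c1=O)Cc1ccccc1`: 20100 nM
- compound 2 `CCN(CCCCn1sc2cc(OC)c(OC)cc2c1=O)Cc1ccccc1OC`: 19400 nM

Both compounds were tested in an assay on isolated protein for inhibition of Amine oxidase [flavin-containing] B (Homo sapiens), read by fluorescence, with a stated time of 30 min; a higher number here means a weaker inhibitor, a lower number a stronger inhibitor. Compound 1 gives 20100 nM and compound 2 gives 19400 nM. Within the data shown here, the one measured step between them, a 1.0-fold lower number from compound 1 to compound 2 (0.02 log units; within the scatter), is a methoxy in place of hydrogen on an aromatic carbon. Among the measured compounds shown here, compound 2 therefore stands with the lowest of the two numbers, but its only neighbour, compound 1, lies within the scatter of it, so no order between the two can be claimed.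

Compound 3 `CCN(CCCCn1sc2cc(OC)c(OC)cc2c1=O)Cc1ccc(N(C)C)cc1` has not yet been measured in this assay. It differs from compound 2 in one place: 4-(dimethylamino)phenyl in place of 2-methoxyphenyl on a saturated chain carbon bound to an amine nitrogen. For the measured compounds named here, only the step from compound 1 to compound 2 bears on this change, since it also altered a substituent on the same ring, and that step stayed within the scatter. Nothing measured speaks to a dimethylamino group on this ring. Compound 3 is therefore expected to give 19000 nM, with a range of 7000 nM to 50000 nM, corresponding to an expected step of a 1.0-fold lower number from compound 2 to compound 3 (0.01 log units; within the scatter), that is, none beyond the scatter.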

Compound 3, half-maximal inhibitory concentration: 18800 nM
Compound 3: the middle estimate sits 1.0-fold (0.00 log units) above what was measured; low and high end bracket the measured number.
By their numbers in this assay, from the lowest: compounds 3, 2 and 1 (each within the scatter of the next).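

In this assay, the exchange of 2-methoxybenzyl for 4-(dimethylamino)benzyl gives a 1.0-fold lower number from compound 2 to compound 3 (0.01 log units; within the scatter) and stays within the scatter, so this position now has a second substituent to set against methoxy, with a different name and a different place on the ring, and still no separation. The comparison with the unsubstituted benzyl compound reads the same way: adding the dimethylamino group to this ring gives a 1.1-fold lower number from compound 1 to compound 3 (0.03 log units; within the scatter) and also stays within the scatter, so compound 1, compound 2 and compound 3 cannot be put in any order, and neither substituent has shown a measurable effect on this ring. Nothing available offers an explanation for how closely these three values agree.

As far as these compounds go, whether any change on this ring can move the value beyond the scatter remains open, for instance a carboxylic acid or a chlorine in place of these groups. The compounds shown also leave open what a longer chain on the amine nitrogen, or a change in the shared core, would do, since all three keep those parts unchanged.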